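The source may hold more compounds than are shown below. What is called first, only, known or untested is meant among the compounds shown, and "the series" means these compounds.

Working notes on the series around the core of compound 1 `Cc1ccc(S(=O)(=O)c2cnc3ccc(Cl)cc3c2N2CCC(C)CC2)cc1`. In an assay on isolated protein for displacement of a labelled ligand from metabotropic glutamate receptor 5 (Homo sapiens), with a stated time of 60 min, tested at 1 uM (on this read-out lower numbers stand for less inhibition and higher numbers for more inhibition at the one concentration tested (going by the name of the read-out)), compound 1 gives 95%, the highest of the three measured numbers. Compound 3 `CC1CCN(c2c(S(=O)(=O)c3cccc(Cl)c3)cnc3ccc(Cl)cc23)CC1` gives 92% in this assay, and compound 2 `Cc1ccc(S(=O)(=O)c2cnc3ccc(Cl)cc3c2N2CCC(C)CC2)cc1C` gives 84%. The step of a number 3 percentage points lower from compound 1 to compound 3 (within the scatter) and the step of a number 8 percentage points higher from compound 2 to compound 3 (within the scatter) both lie within the scatter, while the step of a number 11 percentage points lower from compound 1 to compound 2 (beyond the scatter) lies beyond it.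

Compound 4 `Cc1ccc(S(=O)(=O)c2cnc3ccc(C)cc3c2N2CCC(C)CC2)cc1` differs from compound 1 by methyl in place of chloro on an aromatic carbon. Going by the values given here, none of the measured steps touches that place: the two steps from compound 1 change the group on the sulfonyl sulfur, and the largest of them, a number 11 percentage points lower from compound 1 to compound 2 (beyond the scatter), is still modest. Among the compounds with values here, no measured step bears directly on the exchange of chloro for methyl on the fused ring. The change to compound 4 is therefore expected to give a step of about a number 7 percentage points lower from compound 1 to compound 4 (within the scatter), not clearly beyond the scatter. Compound 4 is estimated at 88% in this assay, with a range from 75% to 97%.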

Compound 4, a percentage reported as inhibition, at one concentration (the size of the read-out at that concentration, not a potency): 82%
Compound 4: the middle estimate sits 6 percentage points above what was measured; the range from low to high includes it.
By their numbers in this assay, from the lowest: compounds 4, 2, 3 and 1 (each within the scatter of the next, the first and the last beyond it).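

Going by these compounds alone, the first change on the fused ring, methyl in place of chloro on this aromatic carbon, gives a number 13 percentage points lower from compound 1 to compound 4 (beyond the scatter) in this assay and so shows that this position affects the read-out. The step is modest, and so is a number 11 percentage points lower from compound 1 to compound 2 (beyond the scatter) at the sulfonyl aryl group, so a single-carbon change at either site can move the number beyond the scatter, although compound 4 still gives 82% at the one concentration tested. No measurement at hand accounts for the difference between chloro and methyl here.

Going by these compounds, whether fluoro, methoxy, nitrile or an amine at this carbon would match chloro or methyl remains open. Also open, on these data alone, is whether the same exchange would give a similar step with the 3-chlorophenyl group of compound 3 on the sulfonyl sulfur.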